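A few compounds are considered here, and "the series" means these few. Any claim that something is new, unique, unknown or untested is made for them only; others in the source may bear on it.

Measured so far:
compound 1 `O=C(Nc1cc(C(F)(F)F)cc(C(F)(F)F)c1)C1CCc2ccccc2N1C(=O)c1ccccc1Cl` — 5250 nM
compound 2 `CC(=O)N1c2ccccc2CCC1C(=O)Nc1ccccc1O` — 89600 nM

Of the compounds shown here, two have been tested in a functional assay on MDA-MB-231 cells (Homo sapiens) for cytotoxicity, read by sulforhodamine B assay, with a stated time of 72 h; on this read-out higher numbers stand for weaker inhibition of growth and lower numbers for stronger inhibition of growth. Compound 2 `CC(=O)N1c2ccccc2CCC1C(=O)Nc1ccccc1O` gives 89600 nM, the highest of the two numbers and so the weaker growth inhibitor. Among the measured compounds shown here, its only neighbour, compound 1 `O=C(Nc1cc(C(F)(F)F)cc(C(F)(F)F)c1)C1CCc2ccccc2N1C(=O)c1ccccc1Cl`, gives 5250 nM, a gap beyond the usual scatter. The two differ in more than one place, so the numbers alone do not say which part of the structure matters.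

Compound 3 `O=C(Nc1ccccc1O)C1CCc2ccccc2N1C(=O)c1ccccc1Cl` has not been measured. It takes compound 2 and makes one change: 2-chlorophenyl in place of methyl on a carbonyl carbon. The group that enters is the same one compound 1 carries on the carbonyl attached to the amide-type nitrogen in a ring, while the rest of compound 3 stays as in compound 2. With no single-change comparison available, the expectation rests on this shared feature: compound 3 is expected to move towards the stronger end, a step of a 4.5-fold lower number from compound 2 to compound 3 (0.65 log units; beyond the scatter) in this assay, beyond the scatter, though with wide uncertainty. The estimate for compound 3 is 20000 nM, within 5000 nM to 80000 nM.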

Compound 3, concentration for 50% growth inhibition: 47400 nM
Estimate against measurement, compound 3: 2.4-fold (0.37 log units) below, and the stated range covers the measured number.
By their numbers in this assay, from the lowest: compound 1; then compounds 3 and 2 (each within the scatter of the next).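

In this assay, putting 2-chlorophenyl in place of methyl on a carbonyl carbon gives a 1.9-fold lower number from compound 2 to compound 3 (0.28 log units; within the scatter), so swapping a single carbon for a group of seven heavy atoms, with a whole aromatic ring, produces no difference this test can resolve when the rest of the molecule is that of compound 2. The new result also shows that this group alone does not account for the number of compound 1: compound 1 gives 5250 nM, while compound 3, which carries the same group on the same carbonyl, gives 47400 nM. No separate measurement is available to explain why the swap changes so little.

The compounds shown offer only methyl and 2-chlorophenyl at this carbonyl, so it remains open whether a plain phenyl without the chlorine, a longer alkyl chain or a group carrying an amine would read any differently. It is also open whether methyl and 2-chlorophenyl would still read alike if compound 1 supplied the rest of the molecule, as its acetyl counterpart is not among the compounds shown.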